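Replacing the fluoro group of compound 2

This account rests on a few compounds, and the source may have more. Where it says the series, first, only, none or still open, it means among the compounds named here.

Compound 1 `CN(Cc1ccccc1Br)C(=O)c1cc2c(Cc3cccc(Cl)c3)n[nH]c2cc1O`: 130 nM
Compound 2 `CN(Cc1ccc(F)cc1)C(=O)c1cc2c(Cc3cccc(Cl)c3)n[nH]c2cc1O`: 410 nM
Compound 3 `CN(Cc1cccc(NS(C)(=O)=O)c1)C(=O)c1cc2c(Cc3cccc(Cl)c3)n[nH]c2cc1O`: 3200 nM

In a functional assay on A2780 cells (Homo sapiens) for antiproliferative activity, read by resazurin assay, with a stated time of 72 h (a lower number here means a stronger inhibitor, a higher number a weaker inhibitor), compound 2 sits in the middle of the three at 410 nM. On one side lies a 3.2-fold higher number from compound 1 to compound 2 (0.50 log units; beyond the scatter), and on the other lies a 7.8-fold higher number from compound 2 to compound 3 (0.89 log units; beyond the scatter).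

Compound 4 `CN(Cc1ccc(CNS(C)(=O)=O)cc1)C(=O)c1cc2c(Cc3cccc(Cl)c3)n[nH]c2cc1O` differs from compound 2 in one place: (methanesulfonamido)methyl in place of fluoro on an aromatic carbon. This puts (methanesulfonamido)methyl in place of fluoro on an aromatic carbon, para to a large group.

For the measured compounds named here, no measured compound carries this exact group. The nearest evidence is the 3-(methanesulfonamido)phenyl of compound 3, which gave a 7.8-fold higher number from compound 2 to compound 3 (0.89 log units; beyond the scatter) and, measured against the 2-bromophenyl, a 25-fold higher number from compound 1 to compound 3 (1.39 log units; beyond the scatter). Both steps are beyond the scatter and both point to a higher number, so a rise of modest size is expected here too, though the group and its place both differ from those in compound 3.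

The expected change is a 4.9-fold higher number from compound 2 to compound 4 (0.69 log units; beyond the scatter).

For compound 4 the estimate in this assay is 2000 nM, with an expected range of 700 nM to 5500 nM.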

Compound 4, half-maximal inhibitory concentration: 570 nM
Compound 4: the middle estimate sits 3.5-fold (0.55 log units) above what was measured; measured number below the stated range.
By their numbers in this assay, from the lowest: compound 1; then compounds 2 and 4 (each within the scatter of the next); then compound 3.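

In this assay, the exchange of fluoro for (methanesulfonamido)methyl gives a 1.4-fold higher number from compound 2 to compound 4 (0.14 log units; within the scatter). This aromatic carbon, para to a large group, therefore takes a group of 6 heavy atoms in place of 1, including a hydrogen-bond donor, with no change beyond the scatter. The value of compound 3, 3200 nM, can thus no longer stand for every group that carries a methanesulfonamido unit, and nothing available here explains the result.

The compounds shown leave open whether this position would accept other groups, such as a primary amine, a carboxylic acid or a longer sulfonamide chain, in the same way. They also leave open how (methanesulfonamido)methyl would behave elsewhere on this ring.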